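A few compounds are considered here, and "the series" means these few. Any claim that something is new, unique, unknown or untested is made for them only; others in the source may bear on it.

Two acylhydrazone ureas on a shared core were tested for their effect on the growth of gastric cancer cells. Compound 1 `CN(C)CCn1cnnc1-c1cc(Oc2ccc(NC(=O)N/N=C/c3cc(C(C)(C)C)cc(C(C)(C)C)c3O)cc2F)ccn1` carries a di-tert-butyl-substituted hydroxyphenyl group at the hydrazone end; in a functional assay on MKN-45 cells (Homo sapiens) for cytotoxicity, read by MTT assay, with a stated time of 72 h (a lower number here means a stronger inhibitor, a higher number a weaker inhibitor), compound 1 gives 3300 nM. Compound 2 `CN(C)CCn1cnnc1-c1cc(Oc2ccc(NC(=O)N/N=C/c3ccc(O)c(O)c3)cc2F)ccn1` replaces that group with a 3,4-dihydroxyphenyl ring, and in this assay compound 2 gives 3240 nM. Of the two numbers in hand, compound 2 has the lower, but the gap to compound 1 lies within the scatter of repeated runs, so the two cannot be told apart.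

Compound 3 `CN(C)CCn1cnnc1-c1cc(Oc2ccc(NC(=O)N/N=C/c3cccc(O)c3)cc2F)ccn1` has not yet been measured in this assay. It differs from compound 2 in one place: hydrogen in place of hydroxy on an aromatic carbon. Since the two measured compounds agree despite unrelated phenol patterns, the author expects no step beyond the scatter from this change, with a slight lean toward a weaker inhibitor, a 1.2-fold higher number from compound 2 to compound 3 (0.09 log units; within the scatter). Compound 3 is therefore estimated to give 4000 nM in this assay, within a range of 1500 nM to 11000 nM.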

Compound 3, half-maximal inhibitory concentration: 1370 nM
Estimate against measurement, compound 3: 2.9-fold (0.47 log units) above, outside the stated range (below it).
By their numbers in this assay, from the lowest: compound 3; then compounds 2 and 1 (each within the scatter of the next).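

Removing the hydroxy group that sits ortho to a hydroxy group and para to a large group gives, in this assay, a 2.4-fold lower number from compound 2 to compound 3 (0.37 log units; beyond the scatter), a modest step but one beyond the scatter, so this position on the aromatic ring does register in the assay. Compounds 1 and 2 differ in more than one place and could not show what any single position contributes, whereas this pair isolates one. It shows that, on this core, the change from 3,4-dihydroxyphenyl to 3-hydroxyphenyl moves toward a stronger inhibitor, so the second hydroxy group is not required for activity against these cells, and no measurement in hand bears on why the number drops.

The compounds shown leave open whether the remaining hydroxy group matters, as a plain phenyl ring would test, and whether a methoxy group or an amine at the vacated position would hold, extend or reverse the step. One step on one scaffold also cannot say whether the same change would give a similar result on a different hydrazone end, such as the di-tert-butyl-substituted ring of compound 1.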